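Replacing the ring of compound 3 with furan-3-yl

A few compounds are considered here, and "the series" means these few. Any claim that something is new, unique, unknown or untested is made for them only; others in the source may bear on it.

In a functional assay on HeLa cells (Homo sapiens) for antiproliferative activity, read by XTT assay, with a stated time of 72 h (on this read-out lower numbers stand for stronger inhibition and higher numbers for weaker inhibition), compound 3 (`C=C(C)CCC[C@]1(C)C2=CCC[C@](C)(C[C@H](O)C3=CC(=O)OC3O)[C@H]2CC[C@H]1C`) gives 3800 nM and compound 2 (`C=C(C)CCC[C@]1(C)C2=CCC[C@](C)(C[C@@H](O)C3=CC(=O)OC3O)[C@H]2CC[C@H]1C`) gives 2600 nM. These two differ at a single stereocentre, and a 1.5-fold higher number from compound 2 to compound 3 (0.16 log units; within the scatter) stays within the scatter. Compound 1 (`C=C(C)CC[C@]1(C)C2=CCC[C@](C)(C[C@H](O)c3ccoc3)[C@H]2CC[C@H]1C`), which also carries furan-3-yl, gives 30200 nM, clearly weaker than compound 3. Compound 4 (`C=C(C)CCC[C@]1(C)C2=CCC[C@](C)(C[C@H](O)c3ccoc3)[C@H]2CC[C@H]1C`) departs from compound 3 by one change: a group of 5 heavy atoms (4 carbon, 1 oxygen; one five-membered aromatic ring with 1 hetero atom) in place of a group of 7 heavy atoms (4 carbon, 3 oxygen; one five-membered non-aromatic ring with 1 hetero atom), on a saturated chain carbon bound to an oxygen on a saturated carbon and a saturated chain carbon. Among the measured compounds shown here, the stereocentre step does not touch this ring, so the only guide is compound 1 at 30200 nM, though it is not identical to compound 4 elsewhere. A move to a higher number in this assay is therefore expected, with an estimated 5.3-fold higher number from compound 3 to compound 4 (0.72 log units; beyond the scatter). The estimate for compound 4 is 20000 nM, with an expected range of 8000 nM to 50000 nM.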

Compound 4, half-maximal inhibitory concentration: 59400 nM
Beside the measured number, compound 4's estimate is 3.0-fold (0.47 log units) below it; the whole stated range lies below it.
By their numbers in this assay, from the lowest: compounds 2 and 3 (each within the scatter of the next); then compounds 1 and 4 (each within the scatter of the next).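

In this assay, putting furan-3-yl in place of the non-aromatic ring on this saturated chain carbon gives a 16-fold higher number from compound 3 to compound 4 (1.19 log units; beyond the scatter), and the same ring change gives a 23-fold higher number from compound 2 to compound 4 (1.36 log units; beyond the scatter), so the ring at this position has a large effect on the number. The chain elsewhere counts for far less here: 2-methylprop-2-en-1-yl in place of 1-methylethenyl gives a 2.0-fold higher number from compound 1 to compound 4 (0.29 log units; within the scatter).

As far as these compounds go, whether a carboxylic acid or an amine at this position would keep the activity stays open. Nothing at hand explains the large effect of the ring change.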